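Extending the chain on compound 1 toward compound 3

The compounds below may be only part of what the source reports. "The series", "measured", "known", "first", "only" and "open" are said of these compounds alone.

Compound 1 `Cn1c(N)c(-c2nc3ccccc3[nH]2)c2nc(C#N)c(C#N)nc21` is characterised in a functional assay on HeLa cells (Homo sapiens) for antiproliferative activity, read by MTT assay, with a stated time of 48 h (a higher number here means a weaker inhibitor, a lower number a stronger inhibitor), only by a limit: compound 1 gives > 50000 nM, which is a limit of the assay and not a number. Compound 2 `CN1CCN(CCn2c(N)c(-c3nc4ccccc4[nH]3)c3nc(C#N)c(C#N)nc32)CC1` likewise gives > 50000 nM, again a limit. Among the measured compounds shown here, the single measured step that the two limits leave unreadable from compound 1 to compound 2 is therefore unreadable, as both ends sit at the same limit (the limit of > 50000 nM in this assay, at which 2 of the 2 values shown sit). Compound 3 `N#Cc1nc2c(-c3nc4ccccc4[nH]3)c(N)n(CCCN3CCCCC3)c2nc1C#N` differs from compound 1 by 2-(piperidin-1-yl)ethyl in place of hydrogen on a saturated chain carbon bound to an aromatic nitrogen. For the measured compounds named here, the only comparable step, with a larger ring-bearing chain entering at the same place, gave no readable change, so no step beyond the scatter can be read from it. Compound 3 is accordingly expected to remain at 50000 nM, with a range from 15000 nM to 150000 nM. The expected step of a number no higher from compound 1 to compound 3 (the limit leaves the size open) is estimated to be nothing that the assay could resolve.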

Compound 3, half-maximal inhibitory concentration: 6680 nM
Compound 3: the middle estimate sits 7.5-fold (0.87 log units) above what was measured; measured number outside the range, below it.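

In this assay, the place on the saturated chain carbon bound to an aromatic nitrogen now shows that it can respond to substitution, with an at least 7.4-fold lower number from compound 1 to compound 3 (0.87 log units; beyond the scatter). The ring-bearing chain itself matters too, as the outcome depends on which chain enters, with an at least 7.4-fold lower number from compound 2 to compound 3 (0.87 log units; beyond the scatter), so compound 2 goes against any claim that a ring-bearing chain at this place is enough. Both steps start from a limit and give only a minimum size, and compound 3 is the only compound here with a number: the limit of > 50000 nM in this assay, at which 2 of the 3 values shown sit.

The step from compound 2 to compound 3 changes chain length and terminal ring together, so the compounds shown do not separate the two. From the compounds shown here alone, it also remains open how a longer chain, or a morpholine ring at the end of the same chain, would read.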